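Sulfonamide aryl changes: removing bromo from compound 3

A few compounds are considered here, and "the series" means these few. Any claim that something is new, unique, unknown or untested is made for them only; others in the source may bear on it.

Measured in an assay on HEK293 cells for displacement of a labelled ligand from 5-hydroxytryptamine receptor 6 (Homo sapiens), with a stated time of 60 min, tested at 1 uM, in the presence of a further agent that is not named here; on this read-out lower numbers stand for a weaker effect and higher numbers for a stronger effect at the one concentration tested:
compound 1 `COc1cc(N)c(Cl)cc1C(=O)CCC1CCN(CCNS(=O)(=O)c2cc(Br)ccc2Br)CC1` gives 52%
compound 2 `COc1ccc(S(=O)(=O)NCCN2CCC(CCC(=O)c3cc(Cl)c(N)cc3OC)CC2)cc1Cl` gives 85%
compound 3 `COc1ccc(S(=O)(=O)NCCN2CCC(CCC(=O)c3cc(Cl)c(N)cc3OC)CC2)cc1Br` gives 72%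

Compound 3 stands second of the three in this assay: below compound 2, as a number 13 percentage points lower from compound 2 to compound 3 (beyond the scatter) shows, and above compound 1, as a number 20 percentage points higher from compound 1 to compound 3 (beyond the scatter) shows. Compound 4 `COc1ccc(S(=O)(=O)NCCN2CCC(CCC(=O)c3cc(Cl)c(N)cc3OC)CC2)cc1` differs from compound 3 by hydrogen in place of bromo on an aromatic carbon. Going by the values given here, no measured step removes a halogen outright; the nearest is a number 13 percentage points lower from compound 2 to compound 3 (beyond the scatter), a modest swap of one halogen for another, while a number 33 percentage points higher from compound 1 to compound 2 (beyond the scatter) and a number 20 percentage points higher from compound 1 to compound 3 (beyond the scatter) change the whole aryl group. A modest step is therefore expected, direction uncertain, leaning lower. Compound 4 is expected to give about 60% in this assay, between 40% and 80%, a step of a number 12 percentage points lower from compound 3 to compound 4 (beyond the scatter).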

Compound 4, a percentage reported as inhibition, at one concentration (the size of the read-out at that concentration, not a potency): 52%
Compound 4: the middle estimate sits 8 percentage points above what was measured; measured number inside the range.
By their numbers in this assay, from the lowest: compounds 1 and 4 (each within the scatter of the next); then compound 3; then compound 2.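

Hydrogen ortho to a methoxy group falls short of both halogens in this assay (a number 20 percentage points lower from compound 3 to compound 4 (beyond the scatter); a number 33 percentage points lower from compound 2 to compound 4 (beyond the scatter)), so this place matters, and the bromo and chloro steps together show that a halogen there is worth keeping. The methoxy group without that halogen does not carry the aryl group clear of 2,5-dibromophenyl (no change at the digits printed from compound 1 to compound 4 (within the scatter)). Nothing measured here accounts for the halogen's contribution.

From the compounds shown here alone, whether fluoro, methyl, trifluoromethyl or an amine in that place would match chloro remains open. Also open, going by these compounds, is whether the halogen would hold its value with the methoxy group replaced by hydrogen.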